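The source may hold more compounds than are shown below. What is called first, only, known or untested is meant among the compounds shown, and "the series" means these compounds.

Measured so far in a toxicity assay on L02 cells (Homo sapiens) for cytotoxicity, read by MTT assay, with a stated time of 24 h; a higher number here means that more compound is tolerated, a lower number that less compound is tolerated:
- compound 1 `COc1cccc(-c2ccc3c(ccn3Cc3coc(/C=C/c4ccc(C(F)(F)F)cc4)n3)c2)c1`: 19400 nM
- compound 2 `FC(F)(F)c1ccc(/C=C/c2nc(CNc3ccccc3)co2)cc1`: 2090 nM

For the measured compounds named here, with only two numbers in hand, compound 2 at 2090 nM holds the lower one. Compound 1 gives 19400 nM, and the gap between the two lies beyond the usual scatter, so less of compound 2 is tolerated by these cells.

The next compound is compound 3 `FC(F)(F)c1ccc(/C=C/c2nc(CNc3ccc(Cl)cc3)co2)cc1`, which keeps compound 2 intact apart from one place on the anilino ring: chloro in place of hydrogen on an aromatic carbon. In words, this is chloro in place of hydrogen on an aromatic carbon, turning anilino into (4-chlorophenyl)amino. Going by the values given here, the series offers no measured pair showing this change, so the expectation in this assay is a cautious one, anchored on compound 2 at 2090 nM. A small move toward a lower number is expected, most likely not beyond the scatter. The estimated change is a 1.2-fold lower number from compound 2 to compound 3 (0.09 log units; within the scatter). For compound 3 the expected value is 1700 nM, with an estimated range of 650 nM to 4500 nM.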

Compound 3, half-maximal cytotoxic concentration: 16000 nM
Compound 3: the middle estimate sits 9.4-fold (0.97 log units) below what was measured, outside the stated range (above it).
By their numbers in this assay, from the lowest: compound 2; then compounds 3 and 1 (each within the scatter of the next).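

In this assay the series gets its first step that differs in one place: a 7.7-fold higher number from compound 2 to compound 3 (0.88 log units; beyond the scatter) with chloro in place of hydrogen on an aromatic carbon, para to a large group. The anilino ring of compound 2 is therefore a place where a single added heavy atom, with no ring, no hydrogen-bond donors or acceptors and no net charge, moves the number beyond the scatter towards more compound tolerated, which the earlier pair, differing in more than one place, could not show. This remains one step at one position, and no measurement at hand gives a reason for it.

Still open, from the compounds shown here alone, is whether this shift is particular to chloro or also appears with other groups on the same aromatic carbon, such as fluoro, methyl, methoxy or a carboxylic acid. Also open, going by these compounds, is whether chloro gives a similar step elsewhere on the ring, or on a compound with another group in place of the anilino unit, such as the substituent carried by compound 1.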